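Sulfanyl substituent changes on the acylguanidine series

A few compounds are considered here, and "the series" means these few. Any claim that something is new, unique, unknown or untested is made for them only; others in the source may bear on it.

Measured so far:
compound 1, `Cc1cc(Cl)c(S(C)(=O)=O)cc1C(=O)N=C(N)N`, in a functional assay for inhibition of sodium/hydrogen exchanger (Oryctolagus cuniculus) (on this read-out higher numbers stand for weaker inhibition and lower numbers for stronger inhibition), compound 1 gives 25 nM
compound 2, `CCCSc1cc(C)c(C(=O)N=C(N)N)cc1S(C)(=O)=O`, in this assay compound 2 gives 6.8 nM
compound 3, `Cc1cc(SC(C)C)c(S(C)(=O)=O)cc1C(=O)N=C(N)N`, in this assay compound 3 gives 12 nM

Compound 3 stands second highest of the three numbers. Its nearest neighbour is compound 2: a 1.8-fold higher number from compound 2 to compound 3 (0.25 log units; within the scatter). Against compound 1 the gap is larger: a 2.1-fold lower number from compound 1 to compound 3 (0.32 log units; beyond the scatter). Both sulfanyl-bearing compounds therefore sit at lower numbers than compound 1, the other such step being a 3.7-fold lower number from compound 1 to compound 2 (0.57 log units; beyond the scatter).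

Compound 4, `Cc1cc(Sc2ccncc2)c(S(C)(=O)=O)cc1C(=O)N=C(N)N`, is the next step from compound 3. The change is pyridin-4-yl in place of isopropyl on a sulfur.

Among the measured compounds shown here, of the measured steps, only the one on the sulfur itself bears on this: a 1.8-fold higher number from compound 2 to compound 3 (0.25 log units; within the scatter), a swap of one alkyl shape for another that stayed within the scatter. The two steps from compound 1 concern the entry of the sulfanyl group and say nothing about what hangs on the sulfur. For the measured compounds named here, no measured step exchanges an alkyl for an aromatic ring at this position, so the series gives no direction for such a change. The expectation is therefore a number close to that of compound 3, no change at the digits printed from compound 3 to compound 4 (within the scatter), with a wide allowance for the untested ring. Compound 4 is estimated at 12 nM, range 4 nM to 40 nM.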

Compound 4, half-maximal inhibitory concentration: 13 nM
For compound 4 the middle estimate is 1.1-fold (0.03 log units) below the measured one; the range from low to high includes it.
By their numbers in this assay, from the lowest: compounds 2, 3, 4 and 1 (each within the scatter of the next, the first and the last beyond it).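

In this assay the sulfur carries an aromatic ring as readily as an alkyl group: pyridin-4-yl in place of isopropyl gives a 1.1-fold higher number from compound 3 to compound 4 (0.03 log units; within the scatter), and pyridin-4-yl in place of propyl gives a 1.9-fold higher number from compound 2 to compound 4 (0.28 log units; within the scatter), so neither swap separates the compounds beyond the scatter, even with 6 heavy atoms entering where 3 leave in the first case. The step from the chloro compound, a 1.9-fold lower number from compound 1 to compound 4 (0.28 log units; within the scatter), stays within the scatter, unlike the steps from compound 1 to compound 2 and to compound 3, but this is a thin distinction, as compound 4 lies within the scatter of both of those compounds. Nothing in the data at hand offers an explanation for these results.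

On these data alone, what a phenyl on the sulfur would give, with no ring nitrogen, remains open, as does the outcome for a pyridin-3-yl ring. Also open, as far as these compounds go, are a longer chain such as hexyl on the sulfur and an amine in place of the sulfur-linked group on the aromatic carbon.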